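This account rests on a few compounds, and the source may have more. Where it says the series, first, only, none or still open, it means among the compounds named here.

Measured so far:
Compound 1, `CC(=O)NC[C@H]1CN(c2ccc(OC[C@@H](O)CNc3ccccc3)c(F)c2)C(=O)O1`, gives 124000 nM.
Compound 2, `CC(=O)NC[C@H]1CN(c2ccc(OC[C@H](O)CNc3ccccc3)c(F)c2)C(=O)O1`, gives 296000 nM.

In a physicochemical assay for solubility, read by HPLC (on this read-out lower numbers stand for lower solubility and higher numbers for higher solubility), compound 2 stands highest of the two, its nearest neighbour being compound 1, the step of a 2.4-fold higher number from compound 1 to compound 2 (0.38 log units; beyond the scatter) having been seen because of the fact that compounds 1 and 2 differ only in the configuration as drawn.

Compound 3, `CC(=O)NC[C@H]1CN(c2ccc(OC[C@H](O)CNc3ccc(C#N)cc3)c(F)c2)C(=O)O1`, carries one change against compound 2: cyano in place of hydrogen on an aromatic carbon, placed para to a large group. Among the measured compounds shown here, no measured step touches a change of this kind; the only measured step concerns a stereocentre and is of modest size. For compound 3 the expected step is a 1.5-fold lower number from compound 2 to compound 3 (0.17 log units; within the scatter), within the scatter, so the estimate for compound 3 is 200000 nM, ranging from 80000 nM to 450000 nM.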

Compound 3, solubility: 69000 nM
For compound 3 the middle estimate is 2.9-fold (0.46 log units) above the measured one; the whole stated range lies above it.
By their numbers in this assay, from the lowest: compounds 3 and 1 (each within the scatter of the next); then compound 2.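

Replacing hydrogen with cyano, which turns phenyl into 4-cyanophenyl, gives in this assay a 4.3-fold lower number from compound 2 to compound 3 (0.63 log units; beyond the scatter), so the read-out responds to a change at this aromatic carbon. Among the compounds shown here, the earlier step involved only a stereocentre, so this is the first measured change of a group on this ring. Nothing available explains the direction or size of this step.

From the compounds shown here alone, it remains open whether an amine or a carboxylic acid at this place would shift the number the same way. Going by these compounds, it is also open whether cyano would do so in the configuration of compound 1.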